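Swapping the pendant aryl on a pyrazoline-bearing oxindole core

The source may report more compounds than this note shows. Statements on the series, on what has been measured and on what is new or still open speak of the compounds shown alone.

Measured compounds:
- compound 1, `O=C1N=C(N2N=C(c3ccccc3)CC2c2ccccc2O)S/C1=C1/C(=O)Nc2ccccc21`: 2130 nM
- compound 2, `O=C1N=C(N2N=C(c3ccccc3)CC2c2ccccc2O)S/C1=C1/C(=O)Nc2ccc(Br)cc21`: 240 nM
- compound 3, `Cc1ccc2c(c1)/C(=C1\SC(N3N=C(c4ccccc4)CC3c3ccc(Cl)cc3)=NC1=O)C(=O)N2`: 240 nM

In a functional assay on cells (Cancer cell lines, Homo sapiens) for cytotoxicity, read by sulforhodamine B assay, with a stated time of 48 h (on this read-out higher numbers stand for weaker inhibition of growth and lower numbers for stronger inhibition of growth), compound 1 gives 2130 nM, the highest of the three numbers, so it is the weakest grower-inhibitor in this set. Compound 2 differs from it only by bromo in place of hydrogen on an aromatic carbon, and that single change gave an 8.9-fold lower number from compound 1 to compound 2 (0.95 log units; beyond the scatter). Compound 3 differs from compound 1 in more than one place, so beside compound 1 the value of compound 3, 240 nM, can only be noted, not traced to one change.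

The unmeasured compound 4, `CN(C)c1ccc(C2CC(c3ccccc3)=NN2C2=NC(=O)/C(=C3\C(=O)Nc4ccccc43)S2)cc1`, changes compound 1 elsewhere: 4-(dimethylamino)phenyl in place of 2-hydroxyphenyl on a saturated ring carbon. Among the compounds with values here, no measured step touches this position; the only single-change step seen sits on the other aromatic ring. Compound 3, which carries a 4-substituted phenyl on the same saturated ring carbon, gives a lower number, but it also carries a methyl on the oxindole ring. With no direct guide, compound 4 is expected to stay close to compound 1, with a 1.4-fold lower number from compound 1 to compound 4 (0.15 log units; within the scatter) estimated as no step beyond the scatter. The estimate for compound 4 is 1500 nM, within 450 nM to 5000 nM.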

Compound 4, concentration for 50% growth inhibition: 1110 nM
The estimate for compound 4 lay 1.4-fold (0.13 log units) above the measured number; the measured number falls inside the stated range.
By their numbers in this assay, from the lowest: compounds 2 and 3 (each within the scatter of the next); then compounds 4 and 1 (each within the scatter of the next).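

Putting 4-(dimethylamino)phenyl in place of 2-hydroxyphenyl on a saturated ring carbon gave, in this assay, a 1.9-fold lower number from compound 1 to compound 4 (0.28 log units; within the scatter), so this swap cannot be told apart from no change at all. Within the data shown here, this is the first single change read at this carbon, and it shows that the entering group, with 0 hydrogen-bond donors and 9 heavy atoms, can replace a group with 1 hydrogen-bond donor and 7 heavy atoms without a step beyond the scatter, unlike the bromo change on the other aromatic ring, which gave an 8.9-fold lower number from compound 1 to compound 2 (0.95 log units; beyond the scatter) on the same read-out. Nothing shown offers an explanation for this result.

One swap at this carbon cannot show how far such tolerance extends, and a phenyl ring carrying a carboxylic acid, a plain alkyl chain in place of the aryl ring, or a morpholine ring could behave quite differently. As far as these compounds go, it also remains open whether adding bromo to the core of compound 4 would bring the same gain in growth inhibition as it brought to compound 1.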